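This account rests on a few compounds, and the source may have more. Where it says the series, first, only, none or still open, it means among the compounds named here.

Measured in a physicochemical assay for lipophilicity; on this read-out lower numbers stand for lower lipophilicity and higher numbers for higher lipophilicity:
- compound 1 `Cc1nc(-c2cc(C(F)(F)F)ccc2[C@H]2CCOc3cc(S(=O)(=O)Nc4ccncn4)ccc32)co1`: "not determined" (no result reported)
- compound 2 `Cc1nc(-c2cc(C(F)(F)F)ccc2[C@H]2CCOc3cc(S(=O)(=O)Nc4cccc(F)n4)ccc32)co1`: 4
- compound 3 `Cc1nc(-c2cc(C(F)(F)F)ccc2[C@H]2CCOc3cc(S(=O)(=O)Nc4ncc(F)cn4)ccc32)co1`: 2.8

Of the two compounds with a number, compound 2 stands highest, at 4. Compound 4 `Cn1nccc1-c1cc(C(F)(F)F)ccc1[C@H]1CCOc2cc(S(=O)(=O)Nc3cccc(F)n3)ccc21` differs from compound 2 at one place: 1-methyl-1H-pyrazol-5-yl in place of 2-methyl-1,3-oxazol-4-yl on an aromatic carbon. Within the data shown here, the only measured step, a number 1.20 log units lower from compound 2 to compound 3 (beyond the scatter), is large, but it concerns the group on a sulfonamide nitrogen rather than this place, so it offers no direct guide. Among the measured compounds shown here, no measured step covers this exchange of one five-membered aromatic ring for another. In this assay, the expected change is therefore a number 0.20 log units lower from compound 2 to compound 4 (within the scatter), with no step beyond the scatter anticipated. For compound 4 the estimated value is 3.8, with an expected range from 3.3 to 4.3.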

Compound 4, distribution coefficient: 3.6
For compound 4 the middle estimate is 0.20 log units above the measured one, within the range that was stated.
By their numbers in this assay, from the lowest: compound 3; then compound 4; then compound 2.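

In this assay, the group on the aromatic carbon also moves the number, not only the group on the sulfonamide nitrogen: 1-methyl-1H-pyrazol-5-yl in place of 2-methyl-1,3-oxazol-4-yl gives a number 0.40 log units lower from compound 2 to compound 4 (beyond the scatter). This modest step comes with no change in the counts of heavy atoms, hydrogen-bond donors or hydrogen-bond acceptors. No measured evidence bears on why the step arises. The compounds shown leave open whether this exchange gives a similar step with the 5-fluoropyrimidin-2-yl group of compound 3 on the sulfonamide nitrogen. They also leave open how an amine or a carboxylic acid on that aromatic carbon would read.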